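Amide side chain swap: cyclohexylmethyl to difluorophenyl

A few compounds are considered here, and "the series" means these few. Any claim that something is new, unique, unknown or untested is made for them only; others in the source may bear on it.

Measured compounds:
Compound 1 `Cc1cc(C(=O)Nc2cccc(F)c2)nn1Cc1cc(Cl)ccc1OCc1ccccc1`: 2.8
Compound 2 `Cc1cc(NC(=O)CC2CCCCC2)nn1Cc1cc(Cl)ccc1OCc1ccccc1`: 3.2

For the measured compounds named here, in a physicochemical assay for lipophilicity, at pH 7.4 (on this read-out higher numbers stand for higher lipophilicity and lower numbers for lower lipophilicity), compound 2 gives 3.2, the higher of the two numbers; compound 1 gives 2.8, and the single known step of a number 0.40 log units higher from compound 1 to compound 2 (beyond the scatter) lies beyond the scatter. Compound 3 `Cc1cc(NC(=O)c2c(F)cccc2F)nn1Cc1cc(Cl)ccc1OCc1ccccc1` differs from compound 2 by 2,6-difluorophenyl in place of cyclohexylmethyl on a carbonyl carbon. Going by the values given here, that step in reverse, a fluorinated aryl in place of cyclohexylmethyl, resembles the one step known, so a modest fall is expected, about a number 0.30 log units lower from compound 2 to compound 3 (within the scatter). Compound 3 is therefore estimated at 2.9, within 2.5 to 3.3.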

Compound 3, distribution coefficient: > 3.7
Compound 3: a limit, no number; the forecaster's own chance of this, stated with the estimate: 2%; middle value at least 0.80 log units away from the limit.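

In this assay compound 3 stands at a limit of the assay, not at a number: the limit of > 3.7 in this assay, at which 1 of the 3 values shown sits. For the compounds shown here, at this carbonyl carbon, 2,6-difluorophenyl in place of cyclohexylmethyl gives a number at least 0.50 log units higher from compound 2 to compound 3 (beyond the scatter) and so reverses the order the single earlier step suggested. The change from (3-fluorophenyl)carbamoyl to ((2,6-difluorophenyl)carbonyl)amino gives a number at least 0.90 log units higher from compound 1 to compound 3 (beyond the scatter) even though both groups carry a fluorinated phenyl, so that ring alone does not set the read-out. On these data alone, how far compound 3 lies past its limit remains open. So does the place of an unsubstituted phenyl or an aminomethyl group at this carbonyl carbon.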